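The source may report more compounds than this note shows. Statements on the series, on what has been measured and on what is new or still open speak of the compounds shown alone.

Compound 1 `COc1nc(-c2cccc(Cl)c2)ccc1[C@@H](c1ccccc1)[C@@](O)(CCN(C)C)c1cccc2ccccc12`: in a toxicity assay on Vero cells (Chlorocebus sabaeus) for cytotoxicity (a higher number here means that more compound is tolerated, a lower number that less compound is tolerated), compound 1 gives > 50 ug/mL, which is a limit of the assay rather than a number.
Compound 2 `COc1nc(-c2ccc(Br)cc2)ccc1[C@@H](c1ccccc1)[C@@](O)(CCN(C)C)c1cccc2ccccc12`: compound 2 gives > 50 ug/mL, again a limit.
Compound 3 `COc1nc(-c2cccc(F)c2)ccc1[C@@H](c1ccccc1)[C@@](O)(CCN(C)C)c1cccc2ccccc12`: compound 3 gives > 50 ug/mL, again a limit.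

Compound 2 therefore stands at a limit and not at a measured number, and the two other values shown are limits as well, all three sitting at the same point (the limit of > 50 ug/mL in this assay, at which 3 of the 3 values shown sit). The step to the unmeasured compound 4 `COc1nc(-c2ccc(Cl)cc2)ccc1[C@@H](c1ccccc1)[C@@](O)(CCN(C)C)c1cccc2ccccc12` is a single change on the shared core: chloro in place of bromo on an aromatic carbon.

The measured steps that bear on this change all run between limits: a step that the two limits leave unreadable from compound 1 to compound 2, a step that the two limits leave unreadable from compound 1 to compound 3 and a step that the two limits leave unreadable from compound 2 to compound 3. None of them can be read as a size or a direction, so they give no ground to expect a step beyond the scatter, in either direction, when bromo gives way to chloro.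

Compound 4 is thus expected to return a limit as well, estimated at 60 ug/mL with a range from 30 ug/mL to 150 ug/mL. Within the data shown here, the step that the limit leaves unreadable from compound 2 to compound 4 is expected to be no step that the assay can resolve.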

Compound 4, half-maximal cytotoxic concentration: > 50 ug/mL
Compound 4: a limit, no number (the forecaster's own chance of this, stated with the estimate: 85%); the middle value lies beyond the limit too.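

Compound 4 sits at a limit, as do compound 1, compound 2 and compound 3, so no step among them can be read in this assay: the limit of > 50 ug/mL in this assay, at which 4 of the 4 values shown sit.

The compounds shown leave open how much of each is actually tolerated, and whether chloro and bromo differ at all.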